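The source may hold more compounds than are shown below. What is called first, only, known or untested is meant among the compounds shown, and "the series" means these compounds.

Working notes on the shared core. Compound 1 `CCOC(=O)C1=Cc2ccccc2OC1(OCc1cn(CC(=O)Nc2ccc(OC)cc2)nn1)C(F)(F)F` gives 32700 nM in a functional assay on DU-145 cells (Homo sapiens) for inhibition, read by MTT assay, with a stated time of 24 h; a lower number here means a stronger inhibitor, a higher number a weaker inhibitor. Compound 3 `CCOC(=O)C1=Cc2ccccc2OC1(OCc1cc(-c2ccc(Cl)cc2)no1)C(F)(F)F` gives 18200 nM in this assay. Compound 2 `CCOC(=O)C1=Cc2ccccc2OC1(OCc1cn(CC(=O)Nc2ccccc2Br)nn1)C(F)(F)F` returns only a limit in this assay, namely > 150000 nM. Compound 2 thus stands at the limit of > 150000 nM in this assay, at which 1 of the 3 values shown sits, the weakest point shown. Going by the values given here, the one measured step that touches this position is an at least 4.5-fold higher number from compound 1 to compound 2 (0.66 log units; beyond the scatter), the exchange of 2-bromophenyl for 4-methoxyphenyl on the amide-type nitrogen; no other pair differs in a single place.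

Compound 4 `CCOC(=O)C1=Cc2ccccc2OC1(OCc1cn(CC(=O)Nc2cccc(F)c2)nn1)C(F)(F)F` carries the change (3-fluorophenyl in place of 2-bromophenyl on an amide-type nitrogen). This step reverses the direction of the change that produced compound 2 in the sense of leaving the 2-bromophenyl group again, and the step from compound 1 to compound 2 was at least modest. A return toward the number of compound 1 is therefore the expectation, though no measured aryl amide other than compound 1 anchors the size. Compound 4 is expected at 60000 nM, within 20000 nM to 200000 nM. This estimate means an expected step of an at least 2.5-fold lower number from compound 2 to compound 4 (0.39 log units; beyond the scatter), with a real chance that only a limit is reported.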

Compound 4, half-maximal inhibitory concentration: > 150000 nM
Compound 4: a limit, no number; the forecaster's own chance of this, stated with the estimate: 35%; middle value at least 2.5-fold (0.39 log units) from the limit.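

Moving from 2-bromophenyl to 3-fluorophenyl on the amide-type nitrogen does not yield a number in this assay: compound 4 gives only a limit, > 150000 nM. Set against the 4-methoxyphenyl amide, the new aryl group gives an at least 4.5-fold higher number from compound 1 to compound 4 (0.66 log units; beyond the scatter), so the weaker result at this position is no longer tied to 2-bromophenyl alone. The step between the two halogen-bearing aryl amides cannot be read because both values are limits: the limit of > 150000 nM in this assay, at which 2 of the 4 values shown sit.

The identity of the halogen and its place on the ring change together between compound 2 and compound 4, so the two cannot be separated here. On these data alone, whether an amine or a carboxylic acid on this aryl ring would keep a number near that of compound 1 remains open.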